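Lengthening an Alkyl Carbamate Chain from Compound 2 to Compound 4

A few compounds are considered here, and "the series" means these few. Any claim that something is new, unique, unknown or untested is made for them only; others in the source may bear on it.

compound 1 `COc1ccc(OC(=O)Nc2ccc([Se]C#N)cc2)cc1`: 48200 nM
compound 2 `CCCOC(=O)Nc1ccc([Se]C#N)cc1`: 34400 nM
compound 3 `O=C(Nc1ccc([Se][Se]c2ccc(NC(=O)OCc3ccccc3)cc2)cc1)OCc1ccccc1`: 38600 nM

Of the compounds shown here, three have been measured in a functional assay on MCF7 cells (Homo sapiens) for cytotoxicity, read by MTT assay, with a stated time of 72 h; on this read-out lower numbers stand for stronger inhibition of growth and higher numbers for weaker inhibition of growth. Compound 2 stands at the lowest of the three numbers, but neither of the other two lies beyond the scatter: compound 3 gives 38600 nM and compound 1 gives 48200 nM, so the three are not separated in this assay, and no order among them can be read from these values. Among the measured compounds shown here, no pair of the measured compounds differs in a single place, so no measured step is available as a guide.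

The next compound, compound 4 `CCCCOC(=O)Nc1ccc([Se]C#N)cc1`, differs from compound 2 in one place: methyl in place of hydrogen on a saturated chain carbon, three bonds along the chain from an oxygen next to a carbonyl group. Without a measured step of this kind in the set, the size of the change can only be expected to lie within the scatter of this assay, in no particular direction. The expected step is a 1.1-fold lower number from compound 2 to compound 4 (0.06 log units; within the scatter), a change that is expected not to reach beyond the scatter. Compound 4 is therefore estimated at 30000 nM, with a range from 12000 nM to 80000 nM.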

Compound 4, concentration for total growth inhibition: 20200 nM
Estimate against measurement, compound 4: 1.5-fold (0.17 log units) above, and the stated range covers the measured number.
By their numbers in this assay, from the lowest: compounds 4, 2, 3 and 1 (each within the scatter of the next, the first and the last beyond it).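

The step from propyl to butyl gives the set its first measured single change: in this assay, methyl in place of hydrogen on a saturated chain carbon, three bonds along the chain from an oxygen next to a carbonyl group, gives a 1.7-fold lower number from compound 2 to compound 4 (0.23 log units; within the scatter). The earlier compounds shown here offered no such step, so this position had no measured reading until now. The reading is that adding this one carbon leaves compound 4 within the scatter of compound 2, which means that the butyl chain is accommodated here without a measurable loss, while no gain can be claimed either, and nothing in the data accounts for the size or the direction of the step.

What the compounds shown leave open is whether a longer chain, such as pentyl or hexyl, would carry the number beyond the scatter of compound 2 or leave it where it stands. Equally open, as far as these compounds go, is how this position would respond to a group of another kind at the end of the chain, such as an amine or a carboxylic acid.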